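Shortening the sulfur chain in a quinazoline-type cytotoxicity series

The compounds below may be only part of what the source reports. "The series", "measured", "known", "first", "only" and "open" are said of these compounds alone.

Measured compounds:
compound 1 `CCCCCSc1nc(NCc2ccc([Se]C)cc2)c2ccccc2n1`: 31200 nM
compound 2 `CSc1nc(NCc2ccccc2)c2cccnc2n1`: 25900 nM
compound 3 `COc1ccc(CNc2nc([Se]C)nc3ccccc23)cc1`: > 100000 nM

In an ADME assay on BEAS-2B cells (Homo sapiens) for cytotoxicity, read by MTT assay, with a stated time of 72 h (on this read-out lower numbers stand for stronger inhibition of growth and higher numbers for weaker inhibition of growth), compound 1 gives 31200 nM, and compound 2 gives 25900 nM, two numbers that lie within the usual scatter of each other. Compound 3 reaches only the limit (the limit of > 100000 nM in this assay, at which 1 of the 3 values shown sits), which is a boundary of the assay and not a number. Compound 4 `CSc1nc(NCc2ccc([Se]C)cc2)c2ccccc2n1` is not yet measured; it differs from compound 1 by hydrogen in place of butyl on a saturated chain carbon bound to a sulfur. Among the measured compounds shown here, no directly comparable step between measured compounds exists. The change is expected to shift this assay little, with at most a modest move toward weaker inhibition of growth, so the step of a 1.3-fold higher number from compound 1 to compound 4 (0.11 log units; within the scatter) is estimated to stay within or just beyond the scatter. Compound 4 is therefore expected to give about 40000 nM, between 15000 nM and 100000 nM.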

Compound 4, concentration for 50% growth inhibition: 73500 nM
Beside the measured number, compound 4's estimate is 1.8-fold (0.26 log units) below it; measured number inside the range.
By their numbers in this assay, from the lowest: compounds 2 and 1 (each within the scatter of the next); then compound 4. At a limit, above all of these: compound 3.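

In this assay, going from pentylsulfanyl to methylsulfanyl gives a 2.4-fold higher number from compound 1 to compound 4 (0.37 log units; beyond the scatter), the only step shown that changes a single place. This shows that the chain on the sulfur is not a silent part of the molecule: the shorter chain goes with weaker inhibition of growth, though the move is modest. Nothing shown here accounts for this shift. As far as these compounds go, whether a propyl chain would land between these two numbers remains open, as does the effect of an amine or a carboxylic acid at the end of the chain.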